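This account rests on a few compounds, and the source may have more. Where it says the series, first, only, none or still open, it means among the compounds named here.

Among the measured compounds shown here, compound 1 `COc1cc(O)cc(O)c1C(=O)/C=C/c1ccc(O)cc1` gives 40200 nM in a functional assay on HepG2 cells (Homo sapiens) for inhibition, read by MTT assay, with a stated time of 72 h (a higher number here means a weaker inhibitor, a lower number a stronger inhibitor), the higher of the two numbers measured so far. The nearest measured compound, compound 2 `COc1ccc(/C=C/C(=O)c2c(O)cc(O)cc2OC)cc1`, gives 18100 nM in this assay, and that step, a 2.2-fold lower number from compound 1 to compound 2 (0.35 log units; beyond the scatter), came from a methyl in place of hydrogen on an oxygen on an aromatic ring. Compound 3 `COc1cc(O)cc(O)c1C(=O)/C=C/c1ccc(O)c(O)c1` differs from compound 1 by hydroxy in place of hydrogen on an aromatic carbon. For the measured compounds named here, no measured step involves an added hydroxy, and the single methyl step says little about this change, so no step beyond the scatter is expected, which amounts to a 1.1-fold lower number from compound 1 to compound 3 (0.06 log units; within the scatter). Compound 3 is thus estimated at 35000 nM, within 15000 nM to 80000 nM.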

Compound 3, half-maximal inhibitory concentration: 28700 nM
For compound 3 the middle estimate is 1.2-fold (0.09 log units) above the measured one; the measured number falls inside the stated range.
By their numbers in this assay, from the lowest: compounds 2, 3 and 1 (each within the scatter of the next, the first and the last beyond it).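

Hydroxy in place of hydrogen on an aromatic carbon, ortho to a hydroxy group, is the first change shown on a ring carbon, and in this assay it gives a 1.4-fold lower number from compound 1 to compound 3 (0.15 log units; within the scatter). This position therefore accepts a hydroxy with no clear gain or loss in this read-out. No available evidence explains this result. From the compounds shown here alone, whether an amine or a carboxylic acid at the same position would move the number remains open. So does what this hydroxy would do on compound 2, which carries the methyl on oxygen.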